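A few compounds are considered here, and "the series" means these few. Any claim that something is new, unique, unknown or untested is made for them only; others in the source may bear on it.

Measured compounds in a physicochemical assay for solubility, with a stated time of 18 h, at pH 7.4; a lower number here means a less soluble compound, a higher number a more soluble compound:
compound 1, `COc1cccc(CNCCCNc2ccnc3cc(C4CCCCC4)ccc23)c1O`, gives 4200 nM
compound 2, `FC(F)(F)c1ccc(-c2ccc3c(NCCCNCc4ccco4)ccnc3c2)cc1`, gives 32000 nM
compound 3, `COc1cccc(CNCCCNc2ccnc3cc(CC(C)C)ccc23)c1O`, gives 4200 nM

Compound 3 stands level with compound 1 at the digits shown, and the two together are the lowest of the three numbers. Compound 2 is the furthest from it, with a number higher by an amount beyond the scatter. Among the measured compounds shown here, the only single-change step among the measured compounds runs no change at the digits printed from compound 1 to compound 3 (within the scatter), so exchanging cyclohexyl for isobutyl left the solubility where it was.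

Compound 4, `COc1cccc(CNCCCNc2ccnc3cc(-c4ccc(C(F)(F)F)cc4)ccc23)c1O`, has not yet been measured. It differs from compound 3 in one place: 4-(trifluoromethyl)phenyl in place of isobutyl on an aromatic carbon. For the measured compounds named here, no measured step covers this exchange. Compound 2 carries the same 4-(trifluoromethyl)phenyl group but a different amine side chain, and compound 2 with its value of 32000 nM gives the highest of the three numbers; compound 2 and compound 3 differ in two places, so their gap cannot be read as the size of this one change. Going by the values given here, the one step that is known did not move the number, and the data give no firm direction for this new one. The step of a 1.2-fold lower number from compound 3 to compound 4 (0.08 log units; within the scatter) is therefore estimated to lie within the scatter. The estimate for compound 4 in this assay is 3500 nM, expected to fall between 900 nM and 14000 nM.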

Compound 4, solubility: 32000 nM
Compound 4: the middle estimate sits 9.1-fold (0.96 log units) below what was measured; measured number outside the range, above it.
By their numbers in this assay, from the lowest: compounds 1 and 3 (each within the scatter of the next); then compounds 2 and 4 (each within the scatter of the next).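

At the aromatic carbon of the shared core, this assay now shows a change beyond the scatter: 4-(trifluoromethyl)phenyl in place of isobutyl gives a 7.6-fold higher number from compound 3 to compound 4 (0.88 log units; beyond the scatter), and in place of cyclohexyl it gives a 7.6-fold higher number from compound 1 to compound 4 (0.88 log units; beyond the scatter), whereas the two saturated groups had stood level. On the side chain, 2-hydroxy-3-methoxyphenyl in place of furan-2-yl on the saturated chain carbon bound to an amine nitrogen gives no change at the digits printed from compound 2 to compound 4 (within the scatter), so with 4-(trifluoromethyl)phenyl on the aromatic carbon this exchange leaves the number where it was. Among these four compounds the number therefore follows the group on the aromatic carbon and not the group on the side chain, although only this one pair tests the side chain, and cyclohexyl shows that a ring as such does not set the two levels apart.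

No other measurement bears on why the number moves with this exchange. Open, on these data alone, is whether a plain phenyl group would give the same number as 4-(trifluoromethyl)phenyl, and whether a carboxylic acid at this aromatic carbon would move it further.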